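The source may hold more compounds than are shown below. What is called first, only, known or untested is meant among the compounds shown, and "the series" means these compounds.

Measured in an ADME assay (liver) for metabolic stability, with Liver microsome (Homo sapiens) as the target, using microsomes and NADPH, with a stated time of 30 min, tested at 1 uM; a lower number here means slower removal, a higher number faster removal of the compound:
Compound 1 `Nc1ccc(S(=O)(=O)N2CCN(c3ncc(C(O)(C(F)(F)F)C(F)(F)F)cc3C3CC3)CC2)cn1`: 38 mL.min-1.g-1
Compound 2 `Nc1ccc(S(=O)(=O)N2CCN(c3ncc(C(O)(C(F)(F)F)C(F)(F)F)cc3-c3cccnc3)CC2)cn1`: 17 mL.min-1.g-1

Of these two, compound 2 holds the lower number, and the gap is beyond the usual scatter. Compound 3 `Cc1ccc(-c2cc(C(O)(C(F)(F)F)C(F)(F)F)cnc2N2CCN(S(=O)(=O)c3ccc(N)nc3)CC2)cn1` has not yet been measured. It differs from compound 2 as follows: methyl in place of hydrogen on an aromatic carbon. In other words, pyridin-3-yl becomes 6-methylpyridin-3-yl.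

Among the compounds with values here, the only measured step is modest: a 2.2-fold lower number from compound 1 to compound 2 (0.35 log units; beyond the scatter). It swaps cyclopropyl for pyridin-3-yl, which is a different change, so it offers only a rough guide to size. Within the data shown here, no measured step shows what a methyl in place of hydrogen does here. A small upward move from the 17 mL.min-1.g-1 of compound 2 is therefore expected, possibly no larger than the scatter. The expected change is a 1.3-fold higher number from compound 2 to compound 3 (0.11 log units; within the scatter). Compound 3 is estimated at 22 mL.min-1.g-1, with an expected range from 11 mL.min-1.g-1 to 42 mL.min-1.g-1.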

Compound 3, intrinsic clearance in microsomes: 43 mL.min-1.g-1
Estimate against measurement, compound 3: 2.0-fold (0.29 log units) below, outside the stated range (above it).
By their numbers in this assay, from the lowest: compound 2; then compounds 1 and 3 (each within the scatter of the next).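

In this assay, a single methyl next to the ring nitrogen and para to a large group gives a 2.5-fold higher number from compound 2 to compound 3 (0.40 log units; beyond the scatter), which shows that this place on the pyridin-3-yl group responds to even the smallest carbon addition. The other comparison gives a 1.1-fold higher number from compound 1 to compound 3 (0.05 log units; within the scatter), a gap within the scatter, so 6-methylpyridin-3-yl cannot be told apart from cyclopropyl here, while the unsubstituted pyridin-3-yl of compound 2 stands apart from both. The data given offer no explanation for this step.

The compounds shown leave open whether the step belongs to this place or to the methyl itself. A fluorine, a methoxy or a nitrile at the same place, or a methyl elsewhere on that ring, would separate the two.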